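Adding a Second Chloro to Compound 3

The compounds below may be only part of what the source reports. "The series", "measured", "known", "first", "only" and "open" are said of these compounds alone.

A cell test judges a compound by how little of it is needed to harm the cells. In a functional assay on HeLa cells (Homo sapiens) for cytotoxicity, read by MTT assay, with a stated time of 24 h (a lower number here means a stronger inhibitor, a higher number a weaker inhibitor), compound 1 `COc1ccc(/C=C2\CN(C)C/C(=C\c3ccccc3F)C2=O)cc1OC` gives 14400 nM and compound 2 `COc1cc(/C=C2\CN(C)C/C(=C\c3ccc(F)cc3)C2=O)cc(OC)c1OC` gives 7250 nM as its reading, two values within the usual scatter of each other.

Compound 3 `CN1C/C(=C\c2ccc(Cl)cc2)C(=O)/C(=C/c2cccc([N+](=O)[O-])c2)C1` gives > 20000 nM as its result, which is a limit of the assay and not a number. Compound 3 therefore has no exact place beside compound 1 and compound 2.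

Compound 4 `CN1C/C(=C\c2cccc([N+](=O)[O-])c2)C(=O)/C(=C/c2ccc(Cl)c(Cl)c2)C1` differs from compound 3 in one place chloro in place of hydrogen on an aromatic carbon with chloro in place of hydrogen on an aromatic carbon, ortho to a chloro group, so that 4-chlorophenyl becomes 3,4-dichlorophenyl. Within the data shown here, no pair of measured compounds shows this change on its own, so any expectation here is a loose one. Compound 1 at 14400 nM and compound 2 at 7250 nM show that relatives of compound 3 can give real numbers in this assay and so a modest move toward stronger inhibition is expected, not a large one. The expected change is an at least 1.4-fold lower number from compound 3 to compound 4 (0.15 log units; that floor lies within the scatter) and it may well stay within the scatter. Compound 4 could also return only a limit. Compound 4 is estimated at 14000 nM with an expected range from 6000 nM to 32000 nM on this reading.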

Compound 4, half-maximal inhibitory concentration: 9120 nM
Estimate against measurement, compound 4: 1.5-fold (0.19 log units) above; the measured number falls inside the stated range.
By their numbers in this assay, from the lowest: compounds 2, 4 and 1 (each within the scatter of the next). At a limit, above all of these: compound 3.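

In this assay, turning 4-chlorophenyl into 3,4-dichlorophenyl gives an at least 2.1-fold lower number from compound 3 to compound 4 (0.34 log units; beyond the scatter). Among these compounds, this is the only step here between measured compounds that differ in one place, so it is the first direct sign that a chloro on this aromatic carbon, ortho to a chloro group, goes with a lower number, one that can be read as a real value rather than a limit. The size of the step is only a floor because one of its two ends is a limit, and the true gap could be larger: the limit of > 20000 nM in this assay, at which 1 of the 4 values shown sits.

The compounds shown leave open whether chloro is special at this position, since there is no reading for a bromo, an amine or a carboxylic acid on the same aromatic carbon. They also leave open whether the same change would give a step of similar size in a compound whose other aromatic ring carries different groups, as a single pair cannot show how general the step is.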